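A few compounds are considered here, and "the series" means these few. Any claim that something is new, unique, unknown or untested is made for them only; others in the source may bear on it.

Compound 3 `COc1ccc(-c2nnc(SCC(=O)Nc3ccc(C(C)=O)cc3)n2-c2ccccc2)cc1` gives 58% in a functional assay on the whole organism (strain albino) for inhibition, with Rattus norvegicus as the target, read by paw edema, with stated times of 30 min and 3 h, at a dose of 0.28 mmol/kg by the oral route (on this read-out lower numbers stand for less inhibition and higher numbers for more inhibition at the one dose given (going by the name of the read-out)), the top of the three numbers at hand, though compound 2 `COc1ccc(-c2nnc(SCC(=O)Nc3ccc(/C(C)=N/O)cc3)n2-c2ccccc2)cc1` with 57% and compound 1 `C=CCn1c(SCC(=O)Nc2ccc(C(C)=O)cc2)nnc1-c1ccccc1` with 54% both sit within the scatter of it. Among the compounds with values here, the only single-point step measured, a number 1 percentage points higher from compound 2 to compound 3 (within the scatter), concerns a different part of the molecule and is itself within the scatter. Compound 4 `CC(=O)c1ccc(NC(=O)CSc2nnc(-c3ccccc3)n2-c2ccccc2)cc1` differs from compound 3 by hydrogen in place of methoxy on an aromatic carbon. Within the data shown here, no measured pair shows this change, and the three compounds, differing in several places, give nearly the same number, so no shift beyond the scatter is expected. Compound 4 is estimated at 55%, within 45% to 65%. The expected step of a number 3 percentage points lower from compound 3 to compound 4 (within the scatter) is thus small.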

Compound 4, a percentage reported as inhibition, in the whole organism at one dose (the size of the read-out at that dose, not a potency): 62%
Compound 4: middle estimate off by 7 percentage points, on the low side; the range from low to high includes it.
By their numbers in this assay, from the lowest: compounds 1, 2, 3 and 4 (each within the scatter of the next).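

In this assay, the change from 4-methoxyphenyl to phenyl gives a number 4 percentage points higher from compound 3 to compound 4 (within the scatter), so on this aromatic carbon hydrogen and methoxy are not told apart by this read-out. Phenyl in place of allyl on the aromatic nitrogen gives a number 8 percentage points higher from compound 1 to compound 4 (within the scatter), which also stays inside the scatter. No evidence on the cause of these results is at hand. Still open, on these data alone, is whether another group at the same place, such as an amine or a carboxylic acid, would move the number beyond the scatter.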